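Swapping the amide nitrogen substituent in a sulfonamide series

A few compounds are considered here, and "the series" means these few. Any claim that something is new, unique, unknown or untested is made for them only; others in the source may bear on it.

Compound 1 `CCN(CC)C(=O)CN(c1cc(Cl)ccc1OC)S(=O)(=O)c1ccccc1` reaches only the limit > 20000 nM in a functional assay on SH-SY5Y cells (Homo sapiens), read by MTT assay, with a stated time of 24 h; a higher number here means that more compound is needed for the effect, a lower number that less compound is needed; this value is a limit of the assay, not a number.
Compound 2 `COc1ccc(CNC(=O)CN(c2cc(Cl)ccc2OC)S(=O)(=O)c2ccccc2)cc1` likewise sits at the limit > 20000 nM in this assay.
Compound 3 `COc1ccc(Cl)cc1N(CC(=O)N1CCCCC1)S(=O)(=O)c1ccccc1` gives 14500 nM in this assay.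

Among the compounds with values here, compound 3 therefore holds the only real number among the three, while the other two values are limits (the limit of > 20000 nM in this assay, at which 2 of the 3 values shown sit). The two measured steps into compound 3 are an at least 1.3-fold lower number from compound 1 to compound 3 (0.13 log units; that floor lies within the scatter) and an at least 1.3-fold lower number from compound 2 to compound 3 (0.13 log units; that floor lies within the scatter); their floors lie within the scatter, so they say little beyond the fact that compound 3 is the one that could be measured.

Compound 4 `COc1ccc(Cl)cc1N(CC(=O)Nc1ccc(C(F)(F)F)cc1)S(=O)(=O)c1ccccc1` differs from compound 3 by (4-(trifluoromethyl)phenyl)amino in place of piperidin-1-yl on a carbonyl carbon. Within the data shown here, compound 2 already carried a (4-methoxybenzyl)amino amide and sat at the limit, whereas the piperidin-1-yl amide of compound 3 came in below it; no measured step reproduces the entry of an aromatic anilide, so the direction is open. The expectation for compound 4 is a value near that of compound 3 or somewhat weaker, with a real chance of a limit only: the step of a 1.2-fold lower number from compound 3 to compound 4 (0.08 log units; within the scatter) is the estimated shift. Compound 4 is estimated at 12000 nM, ranging from 3000 nM to 40000 nM.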

Compound 4, half-maximal effective concentration: 3750 nM
The estimate for compound 4 lay 3.2-fold (0.51 log units) above the measured number; the range from low to high includes it.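

In this assay, within the data shown here, the amide position of this series now gives a step with a real size, a 3.9-fold lower number from compound 3 to compound 4 (0.59 log units; beyond the scatter), where the earlier steps offered only floors within the scatter. This shows that the group on the carbonyl carbon can shift the number beyond the scatter, and that with (4-(trifluoromethyl)phenyl)amino in that place, less compound is needed for the effect than with piperidin-1-yl. The other two new steps, an at least 5.3-fold lower number from compound 2 to compound 4 (0.72 log units; beyond the scatter) and an at least 5.3-fold lower number from compound 1 to compound 4 (0.72 log units; beyond the scatter), point the same way, but they are floors rather than full sizes, since each starts from a compound whose value is only a limit of the assay: the limit of > 20000 nM in this assay, at which 2 of the 4 values shown sit.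

With a single anilide among the compounds shown, the step cannot be divided between the aromatic ring, the trifluoromethyl group and the amide hydrogen, all of which enter together. A plain phenylamino group on the same carbonyl carbon would test whether the trifluoromethyl group is needed, and an anilide with a methyl group on its nitrogen would test whether the amide hydrogen matters.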